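The compounds below may be only part of what the source reports. "The series", "measured", "known", "first", "only" and "open" are said of these compounds alone.

Measured compounds:
- compound 1 `CC1=NC(C)=C(C(=O)O)C(c2ccccc2[N+](=O)[O-])/C1=C(\O)OC/C=C/c1ccccc1`: 37000 nM
- compound 2 `CC1=NC(C)=C(C(=O)O)C(c2ccccc2)/C1=C(\O)OC/C=C/c1ccccc1`: 2000 nM
- compound 3 `COC(=O)c1cccc(C2C(C(=O)O)=C(C)N=C(C)/C2=C(/O)OC/C=C/c2ccccc2)c1`: 4600 nM

All three were tested in a functional assay on IMR-32 cells for inhibition of Voltage-dependent N-type calcium channel subunit alpha-1B (Homo sapiens), read by calcium flux; on this read-out higher numbers stand for weaker inhibition and lower numbers for stronger inhibition. Compound 2 gives the lowest number of the three: compound 3 sits nearest, and compound 1 furthest, as the steps show. From compound 1 to compound 2 the number drops sharply, a 19-fold lower number from compound 1 to compound 2 (1.27 log units; beyond the scatter), with hydrogen in place of nitro on an aromatic carbon; from compound 2 to compound 3 it rises, a 2.3-fold higher number from compound 2 to compound 3 (0.36 log units; beyond the scatter), with methoxycarbonyl in place of hydrogen on an aromatic carbon. Compound 4 `CC1=NC(C)=C(C(=O)O)C(c2cccc(Cl)c2)/C1=C(\O)OC/C=C/c1ccccc1` has not yet been measured. It differs from compound 2 by chloro in place of hydrogen on an aromatic carbon, placed meta to a large group, the same ring where compound 3 carries its methoxycarbonyl. The step from compound 2 to compound 3 is the closest comparison, and it was modest. Compound 4 is therefore expected to stay near compound 2, with a step of a 1.3-fold higher number from compound 2 to compound 4 (0.10 log units; within the scatter) that may lie within the scatter. The estimate for compound 4 is 2500 nM, expected between 800 nM and 8000 nM.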

Compound 4, half-maximal inhibitory concentration: 1000 nM
Estimate against measurement, compound 4: 2.5-fold (0.40 log units) above; the measured number falls inside the stated range.
By their numbers in this assay, from the lowest: compounds 4 and 2 (each within the scatter of the next); then compound 3; then compound 1.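

In this assay, chloro in place of hydrogen at this place on the aromatic ring gives a 2.0-fold lower number from compound 2 to compound 4 (0.30 log units; within the scatter), so this position accepts a chlorine without a step beyond the scatter, while the group placed there can still matter: a 4.6-fold lower number from compound 3 to compound 4 (0.66 log units; beyond the scatter) separates chloro from methoxycarbonyl at the same place. The change from 2-nitrophenyl to 3-chlorophenyl gives a 37-fold lower number from compound 1 to compound 4 (1.57 log units; beyond the scatter), which shows that compound 1 also stands well apart from this newly measured phenyl variant. Nothing shown here accounts for the size of these steps.

The compounds shown leave open how a methyl, a methoxy or an amine would read at this same place. They also leave open whether the large step seen with compound 1 follows the nitro group itself or its place on the ring, as 3-nitrophenyl and 2-chlorophenyl would test.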